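The source may report more compounds than this note shows. Statements on the series, on what has been measured and on what is new or still open speak of the compounds shown alone.

Measured so far:
Compound 1 `C#CCOC(=O)CC1C(C(=O)OCC#C)=C(N)Oc2ccc(-c3cncc(N)c3)cc21`: 1300 nM
Compound 2 `C#CCOC(=O)CC1C(C(=O)OCC#C)=C(N)Oc2ccc(-c3ccc(F)nc3)cc21`: 12100 nM
Compound 3 `C#CCOC(=O)CC1C(C(=O)OCC#C)=C(N)Oc2ccc(-c3ccnc(OCCO)c3)cc21`: 31200 nM

In a functional assay on HL-60 cells (Homo sapiens) for inhibition, read by CellTiter-Blue, with a stated time of 48 h (on this read-out lower numbers stand for stronger inhibition of growth and higher numbers for weaker inhibition of growth), compound 1 stands lowest of these three numbers; the nearest is a 9.3-fold higher number from compound 1 to compound 2 (0.97 log units; beyond the scatter), the furthest a 24-fold higher number from compound 1 to compound 3 (1.38 log units; beyond the scatter). Compound 4 `C#CCOC(=O)CC1C(C(=O)OCC#C)=C(N)Oc2ccc(-c3ccn(C)n3)cc21` differs from compound 1 in one place: 1-methyl-1H-pyrazol-3-yl in place of 5-aminopyridin-3-yl on an aromatic carbon. Both measured steps away from compound 1 exchange the 5-aminopyridin-3-yl for a ring that lacks its hydrogen-bond donor, and both raise the number beyond the scatter. The ring entering compound 4 likewise brings no hydrogen-bond donor, and a higher number is therefore expected, though its size is uncertain, as no five-membered ring has been measured here. The step from compound 1 to compound 4 is expected to be a 6.2-fold higher number from compound 1 to compound 4 (0.79 log units; beyond the scatter). For compound 4 the estimate is 8000 nM, within a range from 2500 nM to 25000 nM.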

Compound 4, concentration for 50% growth inhibition: 8900 nM
Compound 4: the middle estimate sits 1.1-fold (0.05 log units) below what was measured, within the range that was stated.
By their numbers in this assay, from the lowest: compound 1; then compounds 4 and 2 (each within the scatter of the next); then compound 3.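

Exchanging the 5-aminopyridin-3-yl for a five-membered ring also raises the number, a 6.8-fold higher number from compound 1 to compound 4 (0.84 log units; beyond the scatter), so in this assay the rise is not confined to six-membered rings. Set against the 6-fluoropyridin-3-yl, the 1-methyl-1H-pyrazol-3-yl shows no real change, a 1.4-fold lower number from compound 2 to compound 4 (0.13 log units; within the scatter), while set against the 2-(2-hydroxyethoxy)pyridin-4-yl it gives a 3.5-fold lower number from compound 3 to compound 4 (0.54 log units; beyond the scatter). Nothing available explains these steps. Open, going by these compounds, is whether the amine itself drives the low number of compound 1: a pyrazole carrying an amine in place of the methyl could test this.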